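A few compounds are considered here, and "the series" means these few. Any claim that something is new, unique, unknown or untested is made for them only; others in the source may bear on it.

Measured compounds:
- compound 1 `ClCc1ccc(Cn2cnc3c(Cl)ncnc32)cc1`, in a functional assay on OVCAR-5 cells (Homo sapiens) for cytotoxicity, read by sulforhodamine B assay, with a stated time of 48 h (a higher number here means that more compound is tolerated, a lower number that less compound is tolerated), compound 1 gives 34700 nM
- compound 2 `ClCc1cccc(Cn2cnc3c(Cl)ncnc32)c1`, in this assay compound 2 gives 8910 nM

Compound 2 holds the lower of the two numbers; compound 1 lies higher, beyond the scatter. Compound 3 `ClCc1cccc(Cn2cnc3c(Cl)nc(Cl)nc32)c1` is not yet measured. It differs from compound 2 by chloro in place of hydrogen on an aromatic carbon, between two ring nitrogen atoms. Among the measured compounds shown here, no measured pair shows this change, so the size of the step is open; a step of at most modest size is expected, in either direction or none beyond the scatter. For compound 3 the estimate is 6000 nM, range 2000 nM to 18000 nM, an expected step of a 1.5-fold lower number from compound 2 to compound 3 (0.17 log units; within the scatter).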

Compound 3, concentration lethal to 50% of the cells: 47900 nM
Compound 3: the middle estimate sits 8.0-fold (0.90 log units) below what was measured, and the stated range ends below it.
By their numbers in this assay, from the lowest: compound 2; then compounds 1 and 3 (each within the scatter of the next).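

In this assay chloro in place of hydrogen on an aromatic carbon, between two ring nitrogen atoms, gives a 5.4-fold higher number from compound 2 to compound 3 (0.73 log units; beyond the scatter) and so more compound is tolerated. This position is therefore not silent: a single added chlorine moves the number upward, beyond the scatter, though one pair gives only one direction and size. Nothing at hand bears on the cause of this step.

Open, as far as these compounds go, is whether an amine or a methoxy group at this position moves the number the same way. Also open, from the compounds shown here alone, is whether the same chloro step recurs on compound 1.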